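Changing the Halogenated Benzyl Group of Compound 1

A few compounds are considered here, and "the series" means these few. Any claim that something is new, unique, unknown or untested is made for them only; others in the source may bear on it.

Compound 1 `CCCn1c(=O)c2nc(-c3cnn(Cc4cc(Cl)ccc4Cl)c3)[nH]c2n(CCC)c1=O` carries a 2,5-dichlorobenzyl group on a saturated chain carbon bound to an aromatic nitrogen of its shared core. In an in vitro assay on HEK293 cells for displacement of a labelled ligand from adenosine receptor A2b (Homo sapiens) (a lower number here means a stronger inhibitor, a higher number a weaker inhibitor), compound 1 gives 29 nM. Compound 2 `CCCn1c(=O)c2nc(-n3cccn3)[nH]c2n(CCC)c1=O` lacks that benzyl arm and the ring that holds it. In this assay compound 2 reaches only the limit of > 5800 nM, which is a limit of the measurement and not a number. So compound 1 holds the only full number among the two measured compounds, and the second value shown is the limit described by the limit of > 5800 nM in this assay, at which 1 of the 2 values shown sits.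

Compound 3 `CCCn1c(=O)c2nc(-c3cnn(Cc4ccccc4C(F)(F)F)c3)[nH]c2n(CCC)c1=O` has not been measured. It differs from compound 1 in one place: 2-(trifluoromethyl)phenyl in place of 2,5-dichlorophenyl on a saturated chain carbon bound to an aromatic nitrogen. Within the data shown here, no pair of measured compounds here is separated by a single change, so the expectation rests on compound 1 alone. From compound 1 to compound 3 a step of a 2.1-fold higher number from compound 1 to compound 3 (0.32 log units; beyond the scatter) is expected, a modest move toward weaker binding that may stay within the usual scatter. Compound 3 is therefore expected to give about 60 nM in this assay, between 15 nM and 250 nM.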

Compound 3, inhibition constant: 37 nM
Compound 3: the middle estimate sits 1.6-fold (0.21 log units) above what was measured; the range from low to high includes it.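

Swapping 2,5-dichlorophenyl for 2-(trifluoromethyl)phenyl on a saturated chain carbon bound to an aromatic nitrogen gives a 1.3-fold higher number from compound 1 to compound 3 (0.11 log units; within the scatter) in this assay, so the two compounds cannot be told apart in this read-out. Both chlorine atoms can leave and a trifluoromethyl group can enter without a change beyond the scatter, the first sign that this place accepts more than one substituted benzyl group, although only these two are shown. Nothing measured here explains why the two groups read alike.

Still open, going by these compounds, is how a plain benzyl group with no substituent, or a benzyl group carrying a methoxy group or an amine, would read in this assay, and so whether the ring needs any substituent at all. Compound 2 gives only > 5800 nM, which is a limit and not a number, and it differs from compound 1 in more than one place, so it cannot show which part of the arm matters most.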